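The source may hold more compounds than are shown below. What is called first, only, known or untested is meant among the compounds shown, and "the series" means these compounds.

Compound 1, `COc1cc2c(cc1OC)C(CC(N)=O)CC2`, gives 24.6% in a functional assay on the whole organism (strain Swiss albino) for inhibition, with Mus musculus as the target, in the writhing test, with stated times of 60 min and 15 min, at a dose of 100 mg/kg by the oral route; a higher number here means more inhibition at the dose given (going by the name of the read-out), a lower number less inhibition.
Compound 2, `CCN(CC)C(=O)CC1CCc2cc(OC)c(OC)cc21`, gives 27.4% in this assay.
Compound 3, `COc1cc2c(cc1OC)C(CC(=O)NC(C)(C)C)CC2`, gives 41.8% in this assay.

Compound 3 stands highest of the three numbers in this assay: the step of a number 17.2 percentage points higher from compound 1 to compound 3 (beyond the scatter) and the step of a number 14.4 percentage points higher from compound 2 to compound 3 (beyond the scatter) both lie beyond the scatter, while the step of a number 2.8 percentage points higher from compound 1 to compound 2 (within the scatter) does not. Compound 4, `CCCCCNC(=O)CC1CCc2cc(OC)c(OC)cc21`, differs from compound 3 by pentyl in place of tert-butyl on an amide-type nitrogen. Among the compounds with values here, the steps that bear on this change are those into compound 3, a number 17.2 percentage points higher from compound 1 to compound 3 (beyond the scatter) and a number 14.4 percentage points higher from compound 2 to compound 3 (beyond the scatter), which show that the group on the amide-type nitrogen moves the number in this assay by a modest amount; no measured step, however, sets a branched alkyl against a straight chain on that nitrogen. An expectation for compound 4 therefore rests on these two modest steps alone, and the step of a number 5.8 percentage points lower from compound 3 to compound 4 (within the scatter) is expected to stay within the scatter, with a slight lean downward. Compound 4 is estimated to give 36% in this assay, within a range of 24% to 48%.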

Compound 4, a percentage reported as inhibition, in the whole organism at one dose (the size of the read-out at that dose, not a potency): 71.7%
The estimate for compound 4 lay 35.7 percentage points below the measured number; measured number outside the range, above it.
By their numbers in this assay, from the lowest: compounds 1 and 2 (each within the scatter of the next); then compound 3; then compound 4.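

In this assay, the amide-type nitrogen proves sensitive to which alkyl group it carries and not merely to whether it carries one: pentyl in place of tert-butyl gives a number 29.9 percentage points higher from compound 3 to compound 4 (beyond the scatter) even though the two groups differ little in heavy-atom count. Pentylamino in place of diethylamino gives a number 44.3 percentage points higher from compound 2 to compound 4 (beyond the scatter) and pentyl in place of hydrogen gives a number 47.1 percentage points higher from compound 1 to compound 4 (beyond the scatter) so this position can move the number by far more than the earlier steps suggested. Nothing available explains why pentyl has this effect.

Going by these compounds, whether the rise goes with chain length or with the absence of branching stays open, as only one straight chain appears here. On these data alone, how a propyl group, a longer chain such as octyl, or a benzyl group on that nitrogen would read also remains open.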